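A few compounds are considered here, and "the series" means these few. Any claim that something is new, unique, unknown or untested is made for them only; others in the source may bear on it.

Working notes on the series. Among the measured compounds shown here, compound 1 `COc1cc(-n2ncnc2-c2cccc([N+](=O)[O-])c2)cc(OC)c1OC` is one of the three measured members; in a functional assay on HL-60 cells (Homo sapiens) for antiproliferative activity, read by MTT assay, with a stated time of 72 h (on this read-out lower numbers stand for stronger inhibition and higher numbers for weaker inhibition), compound 1 reaches only the limit > 10000 nM. Compound 2 `COc1ccc(-n2ncnc2-c2cc(OC)c(OC)c(OC)c2)cc1`, which also bears a 4-methoxyphenyl, gives 6200 nM in this assay. Compound 3 `COc1cc(-n2ncnc2-c2ccc(F)cc2)cc(OC)c1OC` is the starting point of the step followed here; in this assay compound 3 reports only the limit > 10000 nM. On the numbers shown, compound 3 therefore stands at the limit of > 10000 nM in this assay, at which 2 of the 3 values shown sit, so no ordering of compound 3 against compound 1 can be read from them.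

Compound 4 `COc1ccc(-c2ncnn2-c2cc(OC)c(OC)c(OC)c2)cc1` differs from compound 3 by methoxy in place of fluoro on an aromatic carbon. For the measured compounds named here, no measured pair covers this change, so its size is an open question. Going by the values given here, the one comparison at hand is compound 2 , whose methoxy-bearing phenyl yields a measurable 6200 nM. A step of an at least 1.2-fold lower number from compound 3 to compound 4 (0.09 log units; that floor lies within the scatter) is expected, toward stronger inhibition but of modest size, with a real chance that this assay again returns only a limit. Compound 4 is estimated at 8000 nM, within 3000 nM to 30000 nM.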

Compound 4, half-maximal inhibitory concentration: 120 nM
The estimate for compound 4 lay 67-fold (1.82 log units) above the measured number; measured number below the stated range.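

In this assay, methoxy in place of fluoro on an aromatic carbon, para to a large group, gives an at least 83-fold lower number from compound 3 to compound 4 (1.92 log units; beyond the scatter). Among the compounds shown here, this is the first measured pair for the change, and it shows that this one position can by itself separate a compound held at the limit from one with a clearly measured value. The value of compound 3 is only a limit, so the step gives a floor and not a true size: the limit of > 10000 nM in this assay, at which 2 of the 4 values shown sit.

Whether this large step is specific to methoxy stays open, since the compounds shown do not tell how an amine, a hydroxyl or an ethoxy group would read at the same position. Also open, as far as these compounds go, is whether the step holds in any read-out other than this assay.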